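The compounds below may be only part of what the source reports. "The series", "measured", "known", "first", "only" and "open" are said of these compounds alone.

Going by the values given here, in a functional assay on HL-60 cells (Homo sapiens) for cytotoxicity, read by MTT assay (a higher number here means a weaker inhibitor, a lower number a stronger inhibitor), compound 3 `Cc1ccccc1S(=O)(=O)NC(C)C1=CC(=O)c2c(O)ccc(O)c2C1=O` gives 70 nM as the higher of the two numbers so far, and compound 2 `Cc1ccc(S(=O)(=O)NC(C)C2=CC(=O)c3c(O)ccc(O)c3C2=O)cc1` gives 30 nM as the lower. Compound 1 `COc1ccc(S(=O)(=O)NC(C2=CC(=O)c3c(O)ccc(O)c3C2=O)C(C)C)cc1` stands as "not determined" (no result reported) and offers no number for comparison. The next structure is compound 4 `COc1ccc(S(=O)(=O)NC(C)C2=CC(=O)c3c(O)ccc(O)c3C2=O)cc1` and its difference from compound 3 is 4-methoxyphenyl in place of 2-methylphenyl on a sulfonyl sulfur with 4-methoxyphenyl in place of 2-methylphenyl on a sulfonyl sulfur. Among the compounds with values here, the one measured step that bears on this is a 2.3-fold higher number from compound 2 to compound 3 (0.37 log units; beyond the scatter) and it is modest, with 2-methylphenyl in place of 4-methylphenyl on a sulfonyl sulfur. Within the data shown here, no measured pair sets 4-methoxyphenyl against 4-methylphenyl, and compound 1 carries 4-methoxyphenyl without a number, so the range stays wide. Since compound 2 reads 30 nM with 4-methylphenyl, a modest shift to a lower number is expected in this assay and no large one. The expected move is a 2.0-fold lower number from compound 3 to compound 4 (0.30 log units; within the scatter) as estimated from that single step. For compound 4 the estimated value is 35 nM with 12 nM to 90 nM as the expected range.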

Compound 4, half-maximal inhibitory concentration: 20 nM
For compound 4 the middle estimate is 1.8-fold (0.24 log units) above the measured one, and the stated range covers the measured number.
By their numbers in this assay, from the lowest: compounds 4 and 2 (each within the scatter of the next); then compound 3.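

In this assay, a 3.5-fold lower number from compound 3 to compound 4 (0.54 log units; beyond the scatter) is a second step beyond the scatter that sets 2-methylphenyl on the sulfonyl sulfur apart, this time against 4-methoxyphenyl rather than 4-methylphenyl. With methoxy in place of methyl on an aromatic carbon, a 1.5-fold lower number from compound 2 to compound 4 (0.18 log units; within the scatter) leaves compound 2 and compound 4 indistinguishable in this series, so among these three compounds the step out of 2-methylphenyl is the only change that reads beyond the scatter. Nothing here gives a reason for either step.

The compounds shown leave open whether an amine or a carboxylic acid on the phenyl ring would stay level with methyl and methoxy. A longer chain such as ethoxy in place of methoxy is equally untested by these compounds.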